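Swapping a ring group for cyanomethyl on a carbonyl carbon

This account rests on a few compounds, and the source may have more. Where it says the series, first, only, none or still open, it means among the compounds named here.

Among the measured compounds shown here, only two compounds have been tested so far in an ADME assay on microsomes from liver (Homo sapiens) for metabolic stability (a lower number here means that the compound disappears faster, a higher number that the compound lasts longer), and they differ in more than one place. Compound 1 `NS(=O)(=O)CC(=O)NCCSc1nonc1/C(=N/O)Nc1cccc(C(F)F)c1` gives > 3 h, which is a limit of the assay and not a number. Compound 2 `CC1(C(=O)NCCSc2nonc2/C(=N/O)Nc2ccc(F)c(C(F)F)c2)CCN1` gives 1.97 h, the only exact half-life available, so it is the one firm reference point.

The next compound, compound 3 `N#CCC(=O)NCCSc1nonc1/C(=N/O)Nc1ccc(F)c(C(F)F)c1`, differs from compound 2 in a single place: a group of 3 heavy atoms (2 carbon, 1 nitrogen; no ring) in place of a group of 5 heavy atoms (4 carbon, 1 nitrogen; one four-membered non-aromatic ring with 1 hetero atom), on a carbonyl carbon. A cyanomethyl group, with no ring, replaces a group carrying a four-membered non-aromatic ring, on a carbonyl carbon.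

For the measured compounds named here, no measured pair yet isolates a change in one place, so the data give no direct guide to the effect of this swap on this assay. The forecast therefore stays close to compound 2 at 1.97 h, with no expected step beyond the usual scatter. The expected change is a 1.2-fold higher number from compound 2 to compound 3 (0.09 log units; within the scatter). For compound 3 the estimated half-life is 2.4 h, with an expected range from 1.1 h to 4.5 h.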

Compound 3, half-life: 2.77 h
The estimate for compound 3 lay 1.2-fold (0.06 log units) below the measured number; the range from low to high includes it.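

In this assay, among the compounds shown here, this is the first step that isolates a single place, and it reads a 1.4-fold higher number from compound 2 to compound 3 (0.15 log units; within the scatter). At this carbonyl carbon, then, the group with the four-membered ring and a hydrogen-bond donor can be replaced by cyanomethyl, which has no ring and no donor, with no step beyond the usual scatter; for this pair, neither the ring nor the donor is needed to keep the half-life in the same range. One pair cannot show how far this holds, and any later gain at this position may be hard to read, given how the values sit against the top of the read-out: the limit of > 3 h in this assay, at which 1 of the 3 values shown sits.

Going by these compounds, it remains open whether other groups on the same carbonyl carbon, such as a plain methyl, a primary amine or a longer chain ending in a carboxylic acid, would also stay within the scatter of compound 3 or would move the half-life clearly. For the compounds shown here, also open is what the ring fluorine shared by compound 2 and compound 3 contributes, as no pair here differs by that atom alone.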